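The source may hold more compounds than are shown below. What is called first, only, known or untested is meant among the compounds shown, and "the series" means these compounds.

Measured compounds:
Compound 1, `O=C(CSc1nnc(-c2ccncc2)o1)N/N=C/c1ccc(Br)cc1`: 21300 nM
Compound 2, `O=C(CSc1nnc(-c2ccncc2)o1)N/N=C/c1cccc(F)c1`: 26700 nM

Both compounds were tested in a functional assay on SW 1116 cells (Homo sapiens) for cytotoxicity, read by MTT assay, with a stated time of 48 h; on this read-out lower numbers stand for stronger inhibition and higher numbers for weaker inhibition. In this assay compound 1 gives 21300 nM, and compound 2 gives 26700 nM. Going by the values given here, the only measured step between them, a 1.3-fold higher number from compound 1 to compound 2 (0.10 log units; within the scatter), lies within the scatter, so the two compounds cannot be told apart on these numbers, and compound 2 stands alongside compound 1 rather than apart from it.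

Compound 3, `O=C(CSc1nnc(-c2ccncc2)o1)N/N=C/c1ccc(O)c(O)c1`, has not yet been measured. It differs from compound 2 in one place: 3,4-dihydroxyphenyl in place of 3-fluorophenyl on a carbon with a double bond to nitrogen. Among the compounds with values here, no measured step involves a ring carrying hydroxyl groups; the single measured step, an exchange of one halogen-bearing ring for another, was within the scatter. Within the data shown here, there is therefore no measured basis for expecting a change in either direction, only the observation that the one ring exchange seen so far left the number where it was. On that basis compound 3 is expected to show a 1.1-fold lower number from compound 2 to compound 3 (0.03 log units; within the scatter), a step not beyond the scatter. The estimate for compound 3 in this assay is 25000 nM, with a range from 8000 nM to 80000 nM, kept wide since the entering group brings hydrogen-bond donors absent from both measured compounds.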

Compound 3, half-maximal inhibitory concentration: 1540 nM
Compound 3: the middle estimate sits 16-fold (1.21 log units) above what was measured; measured number below the stated range.
By their numbers in this assay, from the lowest: compound 3; then compounds 1 and 2 (each within the scatter of the next).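

In this assay, the position on a carbon with a double bond to nitrogen proves sensitive to what it carries, something the two halogen-bearing rings, which could not be told apart, gave no sign of. Putting 3,4-dihydroxyphenyl there in place of 3-fluorophenyl gives a 17-fold lower number from compound 2 to compound 3 (1.24 log units; beyond the scatter), and putting it there in place of 4-bromophenyl gives a 14-fold lower number from compound 1 to compound 3 (1.14 log units; beyond the scatter), so the same ring stands clear of both earlier compounds, with the rest of the molecule unchanged. The entering ring has 2 hydrogen-bond donors and 2 hydrogen-bond acceptors where the leaving 3-fluorophenyl has 0 of each, but that count only describes the change, and nothing available here explains the drop in the number.

The compounds shown do not reveal whether both hydroxyl groups are needed, since no ring with a single hydroxyl group appears among them, and none with methoxy groups in place of the hydroxyl groups. They also leave open how an amine or a carboxylic acid on the ring would compare, and whether other parts of the shared core tolerate change.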